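The compounds below may be only part of what the source reports. "The series", "measured", "known", "first", "only" and "open" are said of these compounds alone.

Working notes on the series. Compound 1 is `Cc1ccccc1S(=O)(=O)Nc1ccc2oc(-c3ccccc3)nc2c1`, compound 2 is `O=S(=O)(Nc1ccc(-c2nc3ccccc3o2)cc1)c1cccc(Cl)c1` and compound 3 is `O=S(=O)(Nc1ccc(-c2nc3ccccc3o2)cc1)c1ccccc1C(F)(F)F`. In an assay on cells for inhibition of HSP60/HSP10 (Homo sapiens), with a stated time of 60 min (on this read-out lower numbers stand for stronger inhibition and higher numbers for weaker inhibition), compound 1 reports only a limit, > 100000 nM. Compound 2 gives 54000 nM, the lowest of the two numbers at hand. Compound 3 gives 74000 nM, which sits within the scatter of compound 2, so no order between the two is claimed. Compound 4, `Cc1cccc(S(=O)(=O)Nc2ccc(-c3nc4ccccc4o3)cc2)c1`, still awaits measurement; it differs from compound 2 by methyl in place of chloro on an aromatic carbon. For the measured compounds named here, no measured pair in the set shows this change, so the expectation rests on the change alone: in this assay the expected step is a 1.3-fold higher number from compound 2 to compound 4 (0.11 log units; within the scatter), none beyond the scatter. Compound 4 is accordingly estimated at 70000 nM, with a range from 30000 nM to 150000 nM.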

Compound 4, half-maximal inhibitory concentration: > 100000 nM
Compound 4 gave a limit, no number; the forecaster's own chance of this, stated with the estimate: 30%; at least 1.4-fold (0.15 log units) between middle value and limit.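

In this assay, for the compounds shown here, the first pair to change only this substituent, 3-chlorophenyl to 3-methylphenyl, gives an at least 1.8-fold higher number from compound 2 to compound 4 (0.26 log units; that floor lies within the scatter). A real loss on replacing chloro with methyl at this place is therefore possible, but none is established beyond the scatter. Compound 4 reports a limit and not a number, so the size of the step stays unread, and the step is only a floor because of that limit: the limit of > 100000 nM in this assay, at which 2 of the 4 values shown sit.

Open, from the compounds shown here alone, is how an amine or a carboxylic acid on this aromatic carbon would read. Also open, going by these compounds, is whether any group here gives a number clearly lower than that of compound 2.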